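Fluorine substituents on the fused benzene ring of the shared core

The source may report more compounds than this note shows. Statements on the series, on what has been measured and on what is new or still open speak of the compounds shown alone.

Measured compounds:
compound 1 `c1cncc(-c2nc3ccccc3n2C2CC2)c1` 49 nM
compound 2 `Fc1cccc2nc(-c3cccnc3)n(C3CC3)c12` 107 nM
compound 3 `Fc1ccc2nc(-c3cccnc3)n(C3CC3)c2c1` 4 nM

In an assay on V79 cells for inhibition of cytochrome P450 11B2, mitochondrial (Homo sapiens), read by HTRF, with a stated time of 1 h (on this read-out lower numbers stand for stronger inhibition and higher numbers for weaker inhibition), compound 1 stands second highest of the three numbers. Compound 2 gives a 2.2-fold higher number from compound 1 to compound 2 (0.34 log units; beyond the scatter), whereas compound 3 gives a 12-fold lower number from compound 1 to compound 3 (1.09 log units; beyond the scatter). Both steps place a single fluoro on an aromatic carbon of the shared core, and the outcome differs sharply with the carbon chosen.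

Compound 4 `FC(F)(F)c1ccc2c(c1)nc(-c1cccnc1)n2C1CC1` carries the change (trifluoromethyl in place of hydrogen on an aromatic carbon). For the measured compounds named here, no measured step introduces a trifluoromethyl, and neither measured fluoro sits on the same carbon, so the two fluoro steps only bracket the possibilities. A step of either sign within that bracket is plausible; the estimate for compound 4 in this assay is therefore a 1.4-fold lower number from compound 1 to compound 4 (0.15 log units; within the scatter), giving an expected 35 nM with a range from 8 nM to 150 nM.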

Compound 4, half-maximal inhibitory concentration: > 10000 nM
Compound 4 gave a limit, no number; the forecaster's own chance of this, stated with the estimate: 2%; middle value at least 280-fold (2.45 log units) away from the limit.
By their numbers in this assay, from the lowest: compound 3; then compound 1; then compound 2. At a limit, above all of these: compound 4.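

In this assay compound 4 gives a limit and not a number: the limit of > 10000 nM in this assay, at which 1 of the 4 values shown sits. Trifluoromethyl in place of hydrogen gives an at least 200-fold higher number from compound 1 to compound 4 (2.30 log units; beyond the scatter), so a single change on the shared core can cost far more than the fluoro steps indicated, where the only rise was a 2.2-fold higher number from compound 1 to compound 2 (0.34 log units; beyond the scatter).

The compounds shown leave open whether this loss belongs to the carbon or to the trifluoromethyl group. A single fluoro or a methyl group on this same carbon would separate the two.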